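Swapping the ring on compound 2: an estimate for compound 4

The source may report more compounds than this note shows. Statements on the series, on what has been measured and on what is new or still open speak of the compounds shown alone.

Measured compounds:
- compound 1 `O=C1O[C@H]([C@@H](O)Cn2ccc(NC(=O)c3ccccc3)nc2=O)C(OCc2ccccc2)=C1OCc1ccccc1`: 8820 nM
- compound 2 `NC1(CCn2ccc(=O)[nH]c2=O)OC(=O)C(OCc2ccccc2)=C1OCc1ccccc1`: > 100000 nM
- compound 3 `O=C1O/C(=C\Cn2ccc(NC(=O)c3ccccc3)nc2=O)C(OCc2ccccc2)=C1OCc1ccccc1`: 8490 nM

All three were tested in an ADME assay on WI-38 cells (Homo sapiens) for inhibition, read by MTT assay, with a stated time of 72 h; on this read-out higher numbers stand for weaker inhibition and lower numbers for stronger inhibition. Compound 1 gives 8820 nM in this assay, and compound 3 gives 8490 nM, two values that sit within the usual scatter of each other. Compound 2 stands apart: its result in this assay is only a limit, > 100000 nM, and not a number, so of the three compounds it is the one that reached the edge of what the assay can report (the limit of > 100000 nM in this assay, at which 1 of the 3 values shown sits).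

The step of interest leads from compound 2 to the as yet unmeasured compound 4 `Nc1ncn(CCC2(N)OC(=O)C(OCc3ccccc3)=C2OCc2ccccc2)c(=O)n1`. The change is a group of 8 heavy atoms (3 carbon, 4 nitrogen, 1 oxygen; one six-membered aromatic ring with 3 hetero atoms) in place of a group of 8 heavy atoms (4 carbon, 2 nitrogen, 2 oxygen; one six-membered aromatic ring with 2 hetero atoms), on a saturated chain carbon, two bonds along the chain from a saturated ring carbon. Among the measured compounds shown here, no step between two measured compounds shares this change, so there is no measured guide to its size or direction. For the measured compounds named here, the only anchor is that compound 2 itself sits at the limit of this assay.

For compound 4, the expectation is that this assay again reports a very weak inhibition or only a limit, with the step that the limit leaves unreadable from compound 2 to compound 4 expected to stay within the scatter. Compound 4 is estimated at 120000 nM, with a range from 30000 nM to 400000 nM.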

Compound 4, half-maximal inhibitory concentration: > 100000 nM
Compound 4: only a limit was reported; the forecaster's own chance of this, stated with the estimate: 70%; the middle value is on the limit's open side.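

Compound 2 and compound 4 both give only a limit in this assay, not a number, so the step between them cannot be read: the limit of > 100000 nM in this assay, at which 2 of the 4 values shown sit.

The compounds shown leave open whether the six-membered aromatic ring with 3 hetero atoms, in place of the one with 2 hetero atoms, changes inhibition at all.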